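The source may hold more compounds than are shown below. What is called first, only, known or untested is meant among the compounds shown, and "the series" means these compounds.

Measured compounds in an ADME assay on Vero cells (Chlorocebus sabaeus) for cytotoxicity, with a stated time of 72 h; a lower number here means a stronger inhibitor, a higher number a weaker inhibitor:
- Compound 1 `CCOC(=O)c1cc(-c2cccc(OCc3cccc(C#N)c3)c2)on1`: > 128000 nM, a limit of the assay rather than a number.
- Compound 2 `CCOC(=O)c1cc(-c2cccc(OCc3ccccc3[N+](=O)[O-])c2)on1`: > 128000 nM, again a limit of the assay.
- Compound 3 `CCOC(=O)c1cc(-c2cccc(OCc3cc(F)ccc3Cl)c2)on1`: "not determined" (no result reported), so no result stands for this compound.

Among the measured compounds shown here, all three share one core, which carries a ring joined through an oxygen to a saturated chain carbon bearing a second aromatic ring; only that outer ring changes. Compound 1 stands at a limit, so its cytotoxicity is known only as weaker than the assay could resolve; the same holds for compound 2. For the measured compounds named here, the one step between measured compounds, a step that the two limits leave unreadable from compound 1 to compound 2, is therefore unreadable, because the limit of > 128000 nM in this assay, at which 2 of the 3 values shown sit, means both ends sit at the same limit.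

Compound 4 `CCOC(=O)c1cc(-c2cccc(OCc3ccc(F)c(F)c3F)c2)on1` differs from compound 1 as follows:
2,3,4-trifluorophenyl in place of 3-cyanophenyl on a saturated chain carbon bound to an oxygen on an aromatic ring

Going by the values given here, no measured step reports what exchanging one outer ring for another does here; the only comparable step, from compound 1 to compound 2, gives no size. The expectation for compound 4 thus rests on compound 1 and compound 2 both sitting at the limit of this assay, so a step that the limit leaves unreadable from compound 1 to compound 4 from compound 1 to compound 4 is expected, meaning no change beyond the scatter. Compound 4 is estimated at 200000 nM, within 90000 nM to 500000 nM, most likely reported again only as a limit.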

Compound 4, half-maximal inhibitory concentration: > 128000 nM
Compound 4: no number, only a limit; the forecaster's own chance of this, stated with the estimate: 80%; the middle value lies beyond the limit too.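

Compound 4 gives > 128000 nM as a limit of the assay, not a number. Neither the step from compound 1 to compound 4 nor the step from compound 2 to compound 4 can be read, for one shared reason: the limit of > 128000 nM in this assay, at which 3 of the 4 values shown sit. The compounds shown leave open whether changing the outer ring alters the cytotoxicity seen in this assay at all.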